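The source may report more compounds than this note shows. Statements on the series, on what has been measured and on what is new or still open speak of the compounds shown alone.

Compound 1 `CC(=O)Nc1c(C(O)(C(F)(F)F)C(F)(F)F)ccc2ccccc12`; in an assay on LtK cells with ATP-sensitive inward rectifier potassium channel 11 (Homo sapiens) as the target (a higher number here means that more compound is needed for the effect, a lower number that less compound is needed), compound 1 gives 18 nM.
Compound 2 `O=C(Nc1c(C(O)(C(F)(F)F)C(F)(F)F)ccc2ccccc12)c1cccc(Br)c1`; compound 2 gives 80 nM.
Compound 3 `O=C(Nc1c(C(O)(C(F)(F)F)C(F)(F)F)ccc2ccccc12)c1ccc(F)cc1`; compound 3 gives 70 nM.

Compound 1 stands lowest of the three numbers, with compound 3 nearest and compound 2 furthest. Compound 4 `CC(=O)Nc1c(C(O)(C(F)(F)F)C(F)(F)F)cc(Br)c2ccccc12` differs from compound 1 by bromo in place of hydrogen on an aromatic carbon. The measured steps all concern the group on the carbonyl carbon: a 4.4-fold higher number from compound 1 to compound 2 (0.65 log units; beyond the scatter), a 3.9-fold higher number from compound 1 to compound 3 (0.59 log units; beyond the scatter), and a 1.1-fold lower number from compound 2 to compound 3 (0.06 log units; within the scatter). None of them touches the ring of the shared core, so the data give no direct guide to this change. Compound 4 is therefore expected to stay close to compound 1, with a step not clearly beyond the scatter, a 1.4-fold higher number from compound 1 to compound 4 (0.14 log units; within the scatter). The estimate for compound 4 in this assay is 25 nM, in a range from 8 nM to 80 nM.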

Compound 4, half-maximal effective concentration: 5310 nM
Compound 4: the middle estimate sits 210-fold (2.33 log units) below what was measured; measured number outside the range, above it.
By their numbers in this assay, from the lowest: compound 1; then compounds 3 and 2 (each within the scatter of the next); then compound 4.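

In this assay, the aromatic carbon para to an acetamido group proves highly sensitive: bromo in place of hydrogen gives a 300-fold higher number from compound 1 to compound 4 (2.47 log units; beyond the scatter). Among these compounds, that step far exceeds those seen on the carbonyl carbon, a 4.4-fold higher number from compound 1 to compound 2 (0.65 log units; beyond the scatter) and a 3.9-fold higher number from compound 1 to compound 3 (0.59 log units; beyond the scatter), so the ring of the shared core can matter more than the group that the earlier compounds varied. Nothing available explains this step.

On these data alone, whether the step belongs to bromo itself remains open, and a fluoro, methyl or amine at this carbon would test that. Also open, as far as these compounds go, is whether the same step would appear with the 3-bromophenyl or 4-fluorophenyl group on the carbonyl carbon.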